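The compounds below may be only part of what the source reports. "The series", "measured", "known", "first", "only" and "open" are said of these compounds alone.

Of the compounds shown here, three sharing one core have been measured in a functional assay on NCI-H460 cells (Homo sapiens) for antiproliferative activity, read by MTT assay, with a stated time of 48 h; on this read-out lower numbers stand for stronger inhibition and higher numbers for weaker inhibition. Compound 1 `COc1cc(-c2cccc3nc(-c4ccccc4)oc23)cc(OC)c1OC` gives 6800 nM. Compound 2 `COc1cc(-c2cccc3nc(-c4ccc(F)cc4)oc23)cc(OC)c1OC`, which adds a fluoro, gives 8700 nM; this is the highest of the three numbers, though the step of a 1.3-fold higher number from compound 1 to compound 2 (0.11 log units; within the scatter) is within the scatter, while compound 3 `COc1cc(-c2cccc3nc(-c4cccc(N)c4)oc23)cc(OC)c1OC`, bearing an amino, gives 2600 nM, and the gap a 3.3-fold lower number from compound 2 to compound 3 (0.52 log units; beyond the scatter) is beyond it.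

The step under study leads from compound 2 to compound 4 `COc1cc(-c2cccc3nc(-c4ccc5cc[nH]c5c4)oc23)cc(OC)c1OC`. The change is 1H-indol-6-yl in place of 4-fluorophenyl on an aromatic carbon.

Among the compounds with values here, two measured steps bear on it. The step of a 3.3-fold lower number from compound 2 to compound 3 (0.52 log units; beyond the scatter) shows that replacing 4-fluorophenyl with a group carrying one hydrogen-bond donor lowered the number by a modest amount, and the step of a 2.6-fold lower number from compound 1 to compound 3 (0.42 log units; beyond the scatter) points the same way. Within the data shown here, the incoming 1H-indol-6-yl likewise carries one hydrogen-bond donor, but it is larger than either phenyl seen so far, and no measured compound tests a fused two-ring group at this position. A modest lowering of the number is therefore expected in this assay, with wide uncertainty.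

Compound 4 is expected to give about 3200 nM, within 1200 nM to 8500 nM, a step of a 2.7-fold lower number from compound 2 to compound 4 (0.43 log units; beyond the scatter).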

Compound 4, half-maximal inhibitory concentration: 24 nM
Compound 4: the middle estimate sits 130-fold (2.12 log units) above what was measured; measured number outside the range, below it.
By their numbers in this assay, from the lowest: compound 4; then compound 3; then compounds 1 and 2 (each within the scatter of the next).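

Within the data shown here, replacing a single phenyl ring at this position, on the aromatic carbon of the five-membered ring next to the ring nitrogen and the ring oxygen, with 1H-indol-6-yl produced in this assay a far larger change than any earlier replacement: a 360-fold lower number from compound 2 to compound 4 (2.56 log units; beyond the scatter) and a 280-fold lower number from compound 1 to compound 4 (2.45 log units; beyond the scatter) are both large, whereas the earlier steps were modest or within the scatter. The change also remains large against the amino-bearing compound, with a 110-fold lower number from compound 3 to compound 4 (2.03 log units; beyond the scatter) showing that the modest effect of 3-aminophenyl did not foretell what this fused two-ring group would do. Nothing available explains the size of these steps.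

The compounds shown do not separate the contribution of the indole ring nitrogen and its hydrogen from that of the fused two-ring shape, a question that naphthyl, benzofuranyl or 1-methylindolyl at this position would address. They also leave open whether the same group would keep this effect if the three methoxy groups of the shared core were replaced by, for instance, hydroxy groups or a single methoxy group.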